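This account rests on a few compounds, and the source may have more. Where it says the series, first, only, none or still open, it means among the compounds named here.

Measured in a functional assay on U2OS cells (Homo sapiens) for antiproliferative activity, read by MTT assay, with a stated time of 72 h; on this read-out lower numbers stand for stronger inhibition and higher numbers for weaker inhibition:
- compound 1 `O=C(CSc1cccc(O)c1)Nc1ccc2nc(NC(=O)c3ccccc3)sc2c1`: > 100000 nM (a limit)
- compound 2 `CCCC(=O)Nc1nc2ccc(NC(=O)CSc3cccc(O)c3)cc2s1`: 10100 nM
- compound 3 `Cc1cc(C)cc(C(=O)Nc2nc3ccc(NC(=O)CSc4ccc(Cl)cc4)cc3s2)c1`: > 100000 nM (a limit)

Not yet measured: compound 4 `Cc1cc(C)cc(C(=O)Nc2nc3ccc(NC(=O)CSc4cccc(O)c4)cc3s2)c1`.

Compound 3 has no number in this assay, only a limit: the limit of > 100000 nM in this assay, at which 2 of the 3 values shown sit. Compound 4 puts 3-hydroxyphenyl in place of 4-chlorophenyl on a sulfur, and keeps the carbonyl group of compound 3 unchanged: 3-hydroxyphenyl in place of 4-chlorophenyl on a sulfur. Going by the values given here, no measured step covers a change at this sulfur. Among the compounds with values here, the one measured step, an at least 9.9-fold lower number from compound 1 to compound 2 (0.99 log units; beyond the scatter), lies at the carbonyl carbon instead, so it bears only indirectly. It shows that the 3-hydroxyphenyl group alone does not secure a measurable value. Compound 4 carries that group with a ring on the carbonyl carbon, and so does compound 1. Compound 1 stays at its limit of > 100000 nM. Compound 2 reaches 10100 nM only with propyl on that carbon. Only a small shift toward lower numbers is therefore expected, an estimated at least 1.6-fold lower number from compound 3 to compound 4 (0.22 log units; that floor lies within the scatter), and compound 4 may well report a limit too. For compound 4 the estimated value is 60000 nM, with an expected range of 15000 nM to 100000 nM.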

Compound 4, half-maximal inhibitory concentration: 2820 nM
For compound 4 the middle estimate is 21-fold (1.33 log units) above the measured one; measured number outside the range, below it.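

In this assay, going by these compounds alone, 3-hydroxyphenyl in place of 4-chlorophenyl on the sulfur gives an at least 35-fold lower number from compound 3 to compound 4 (1.54 log units; beyond the scatter), the first measured step at this position, and it shows that the group on the sulfur can move the read-out strongly while the carbonyl group stays unchanged. The earlier compounds shown here also left it possible that a ring on the carbonyl carbon keeps the number at the limit, but 3,5-dimethylphenyl in place of phenyl gives an at least 35-fold lower number from compound 1 to compound 4 (1.54 log units; beyond the scatter), and in place of propyl it gives a 3.6-fold lower number from compound 2 to compound 4 (0.55 log units; beyond the scatter), so the kind of ring matters. Compound 1 and compound 3 each stand only at a limit, so the two steps that start from them are floors and not full sizes: the limit of > 100000 nM in this assay, at which 2 of the 4 values shown sit.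

From the compounds shown here alone, it remains open whether 4-hydroxyphenyl or 3-methoxyphenyl on the sulfur would behave like 3-hydroxyphenyl. Also open, going by these compounds, is whether 4-chlorophenyl on the sulfur would fare better with propyl on the carbonyl carbon.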